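The source may report more compounds than this note shows. Statements on the series, on what has been measured and on what is new or still open speak of the compounds shown alone.

Among the measured compounds shown here, in a functional assay on T-24 cells (Homo sapiens) for antiproliferative activity (a higher number here means a weaker inhibitor, a lower number a stronger inhibitor), compound 1 `N=C(N)N/N=C/c1cccc(C(=N)N)c1` gives 9100 nM, the only actual number among the three compounds measured. Compound 2 `N=C(N)N/N=C/c1cccc(C(N)=O)c1` is recorded only as a limit, > 184000 nM. Compound 3 `CC/C(=N\N=C(N)N)c1cccc(C(=N)N)c1` is likewise recorded only as a limit, > 152000 nM. For the measured compounds named here, the one measured step, an at least 20-fold higher number from compound 1 to compound 2 (1.30 log units; beyond the scatter), concerns the group on an aromatic carbon, not the site changed next.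

Compound 4 `N=C(NO)N/N=C/c1cccc(C(=N)N)c1` keeps the core of compound 1 and differs in one place: hydroxy in place of hydrogen on an amine nitrogen, with hydroxy in place of hydrogen on an amine nitrogen. Going by the values given here, no measured step touches that nitrogen, so the evidence is indirect. The step of an at least 20-fold higher number from compound 1 to compound 2 (1.30 log units; beyond the scatter) shows that a single change can cost a great deal in this assay, so a weakening beyond the scatter is expected, though a smaller one than that step. The expected change is a 2.7-fold higher number from compound 1 to compound 4 (0.44 log units; beyond the scatter). For compound 4 the estimated value is 25000 nM, with an expected range from 6000 nM to 100000 nM.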

Compound 4, half-maximal inhibitory concentration: 14100 nM
Beside the measured number, compound 4's estimate is 1.8-fold (0.25 log units) above it; measured number inside the range.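

In this assay, the amine nitrogen of compound 1 accepts the change to hydroxyamino without a change that can be read: the result is a 1.5-fold higher number from compound 1 to compound 4 (0.19 log units; within the scatter). Of the single changes shown, the other two end at a limit of the assay, whereas this one keeps a measured number that cannot be told apart from that of compound 1. No measurement shown offers a cause for this result.

Hydroxy is the only group shown on this nitrogen, so whether a methoxy, an amino or a methyl group there would also leave the number in place remains open. Equally open, going by these compounds, is whether hydroxy in place of hydrogen would read the same on another nitrogen of the core of compound 1.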